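The compounds below may be only part of what the source reports. "The series", "measured", "known", "first", "only" and "open" are said of these compounds alone.

Values so far in a functional assay on MGC-803 cells (Homo sapiens) for antiproliferative activity, read by CCK-8 assay, with a stated time of 72 h; on this read-out higher numbers stand for weaker inhibition and lower numbers for stronger inhibition

compound 1 (`O=C(/C=C/c1ccc(CN2CCc3ccccc32)cc1)NO`): "not determined" (no result reported)
compound 2 (`CCc1ccc(OCc2ccc(C(=O)Nc3ccccc3N)cc2)cc1`): 5880 nM
compound 3 (`CCCc1ccc(OCc2ccc(C(=O)Nc3ccccc3N)cc2)cc1`): 4420 nM

In this assay compound 1 has no number, so no step size or direction can be counted from it. Compound 4 (`Nc1ccccc1NC(=O)/C=C/c1ccc(CN2CCc3ccccc32)cc1`) differs from compound 1 by 2-aminophenyl in place of hydroxy on an amide-type nitrogen with 2-aminophenyl in place of hydroxy on an amide-type nitrogen.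

For the measured compounds named here, the one measured step, a 1.3-fold lower number from compound 2 to compound 3 (0.12 log units; within the scatter), is a methyl in place of hydrogen on a saturated chain carbon. Going by the values given here, it is a different change and gives no expected step for compound 4.

Compound 2 at 5880 nM and compound 3 at 4420 nM carry 2-aminophenyl on an amide-type nitrogen, as compound 4 does, and the expectation rests on those two values. Their core differs from that of compound 4, so the range is kept wide.

For compound 4 the expected value is 3000 nM with an estimated range of 700 nM to 12000 nM in this read-out.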

Compound 4, half-maximal inhibitory concentration: > 32000 nM
Compound 4 gave a limit, no number; the forecaster's own chance of this, stated with the estimate: 5%; at least 10-fold (1.02 log units) between middle value and limit.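

In this assay compound 4 gives only a limit, > 32000 nM. Compound 1 has no number here either, so no step can be read between compound 1 and compound 4. From the compounds shown here alone, the size of the change from hydroxy to 2-aminophenyl on the amide-type nitrogen remains open.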